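The source may hold more compounds than are shown below. What is called first, only, known or untested is meant among the compounds shown, and "the series" means these compounds.

Measured compounds in a functional assay on CCRF-CEM cells (Homo sapiens) for antiproliferative activity, with a stated time of 72 h; on this read-out higher numbers stand for weaker inhibition and lower numbers for stronger inhibition: compound 1 `Cc1cccc(CNc2ncnc3c2ncn3[C@@H]2O[C@H](CO)[C@@H](O)[C@H]2O)c1` gives 19100 nM; compound 2 `COc1ccccc1CNc1ncnc2c1ncn2[C@@H]1O[C@H](CO)[C@@H](O)[C@H]1O` gives 3200 nM; compound 3 `OC[C@H]1O[C@@H](n2cnc3c(NCc4cc(F)cc(F)c4)ncnc32)C(O)C1O` gives 24500 nM.

Among these three numbers compound 1 holds the second highest; compound 3 sits within the scatter of it, while compound 2 lies well apart, a 6.0-fold lower number from compound 1 to compound 2 (0.78 log units; beyond the scatter). The unmeasured compound 4 `OC[C@H]1O[C@@H](n2cnc3c(NCc4c(F)ccc(F)c4F)ncnc32)[C@H](O)[C@@H]1O` differs from compound 1 in one place: 2,3,6-trifluorophenyl in place of 3-methylphenyl on a saturated chain carbon bound to a nitrogen on an aromatic ring. For the measured compounds named here, no measured step exchanges a methylphenyl for a fluorinated phenyl on this saturated chain carbon; the only counted step, from compound 1 to compound 2, concerns a methoxyphenyl instead. Compound 3, carrying a difluorophenyl, reads within the scatter of compound 1. Compound 4 is therefore expected to stay close to compound 1, a 1.3-fold lower number from compound 1 to compound 4 (0.10 log units; within the scatter), with an estimate of 15000 nM and a range from 5000 nM to 45000 nM.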

Compound 4, half-maximal inhibitory concentration: 90300 nM
Compound 4: middle estimate off by 6.0-fold (0.78 log units), on the low side, outside the stated range (above it).
By their numbers in this assay, from the lowest: compound 2; then compounds 1 and 3 (each within the scatter of the next); then compound 4.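

For the compounds shown here, exchanging the 3-methylphenyl for 2,3,6-trifluorophenyl on this saturated chain carbon gives a 4.7-fold higher number from compound 1 to compound 4 (0.67 log units; beyond the scatter) in this assay, so a change at this place can also raise the number, whereas the one earlier step lowered it. Set against the 2-methoxyphenyl, the same group gives a 28-fold higher number from compound 2 to compound 4 (1.45 log units; beyond the scatter) and widens the span seen at this place. Nothing available accounts for this rise. The compounds shown leave open how a phenyl carrying a single fluorine would read here. They also leave open how a phenyl carrying an amine or a carboxylic acid would read.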